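The compounds below may be only part of what the source reports. "The series", "measured", "known", "first", "only" and "open" are said of these compounds alone.

Working notes on the series sharing one core, read in a functional assay on OVCAR-3 cells (Homo sapiens) for inhibition, read by MTT assay, with a stated time of 24 h; a lower number here means a stronger inhibitor, a higher number a weaker inhibitor. Compound 1 (`CC1(C)[C@H]2CC[C@]1(C)N(Cc1cn(-c3ccc(C#N)cc3)nn1)C(=O)C2`) gives 380 nM, compound 2 (`CC1(C)[C@H]2CC[C@]1(C)N(Cc1cn(-c3cccc(C#N)c3)nn1)C(=O)C2`) gives 230 nM, and compound 3 (`CC1(C)[C@H]2CC[C@]1(C)N(Cc1cn(-c3ccccc3Cl)nn1)C(=O)C2`) gives 40 nM, the lowest of the three numbers and beyond the scatter of both others. Compound 4 (`CC1(C)[C@H]2CC[C@]1(C)N(Cc1cn(-c3cccc(Cl)c3)nn1)C(=O)C2`) is still unmeasured. The change is 3-chlorophenyl in place of 2-chlorophenyl on an aromatic nitrogen, the same atoms joined differently.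

Within the data shown here, no measured step covers this exact swap, so the evidence is indirect. Among the measured compounds shown here, the only step that keeps the group and relocates it is a 1.7-fold lower number from compound 1 to compound 2 (0.22 log units; within the scatter), which stays within the scatter, but it concerns the cyanophenyl pair. The larger steps are a 9.5-fold lower number from compound 1 to compound 3 (0.98 log units; beyond the scatter) and a 5.8-fold lower number from compound 2 to compound 3 (0.76 log units; beyond the scatter), both beyond the scatter, yet each alters group and placement together and cannot separate the two. For the measured compounds named here, compound 3 with 40 nM sits at the low end of a small set, and compound 2, the one measured 3-cyanophenyl member, gives 230 nM. A modest step to a higher number is therefore expected in this assay, though a result within the scatter remains possible. The estimated step is a 2.5-fold higher number from compound 3 to compound 4 (0.40 log units; beyond the scatter). For compound 4 the expected value is 100 nM, with an estimated range of 30 nM to 320 nM.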

Compound 4, half-maximal inhibitory concentration: 50 nM
Compound 4: middle estimate off by 2.0-fold (0.30 log units), on the high side; low and high end bracket the measured number.
By their numbers in this assay, from the lowest: compounds 3 and 4 (each within the scatter of the next); then compounds 2 and 1 (each within the scatter of the next).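

In this assay, among these compounds, 3-chlorophenyl in place of 2-chlorophenyl gives a 1.3-fold higher number from compound 3 to compound 4 (0.10 log units; within the scatter), so among the chlorophenyl compounds this relocation on the aromatic nitrogen produces no change that can be read, and this is the first measured comparison of placement for the chloro group. Chloro in place of cyano on an aromatic carbon gives a 4.6-fold lower number from compound 2 to compound 4 (0.66 log units; beyond the scatter), the first step to change the group alone, and it shows a difference beyond the scatter that the earlier steps to compound 3 could not separate from placement. 3-Chlorophenyl in place of 4-cyanophenyl, which changes group and placement together, gives a 7.6-fold lower number from compound 1 to compound 4 (0.88 log units; beyond the scatter), so both chlorophenyl compounds stand apart from both cyanophenyl compounds in this set of four, with no compound going against that split, and no measurement shown here bears on the reason for it.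

The compounds shown leave open how a 4-chlorophenyl or a 2-cyanophenyl group would read, which would complete the comparison of the chloro and cyano groups across the placements. They also leave open whether the difference between these two groups extends to a fluoro group, a methoxy group or an amine on the same phenyl ring.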